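Cytotoxicity notes: acetamido to amino on the shared core

The compounds below may be only part of what the source reports. "The series", "measured", "known", "first", "only" and "open" are said of these compounds alone.

Measured so far in an ADME assay on MDBK cells (Bos taurus) for cytotoxicity, read by MTT assay, with a stated time of 96 h; on this read-out lower numbers stand for higher toxicity in this test and higher numbers for lower toxicity in this test:
compound 1, `CC(=O)Nc1ccc(-c2nc3cc(C(F)(F)F)ccc3n2C2CCCCC2)cc1`, gives 17000 nM.
compound 2, `CC(=O)Nc1ccc(-c2nc3cc(C(F)(F)F)ccc3[nH]2)cc1`, gives 50000 nM.

Going by the values given here, compound 1 stands at the lower of the two numbers, i.e. the more toxic end of the pair in this assay; the only neighbour is compound 2, reached by a 2.9-fold higher number from compound 1 to compound 2 (0.47 log units; beyond the scatter), a change of hydrogen in place of cyclohexyl on an aromatic nitrogen.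

The next compound, compound 3, `Nc1ccc(-c2nc3cc(C(F)(F)F)ccc3n2C2CCCCC2)cc1`, differs from compound 1 as follows: hydrogen in place of acetyl on a nitrogen on an aromatic ring. Among the compounds with values here, no measured step touches this position; the single step in hand concerns the aromatic nitrogen and says nothing about the acetyl on the aniline nitrogen. Within this small set there is therefore no basis for expecting a shift beyond the scatter in this assay in either direction, and the working expectation is that compound 3 stays near compound 1.

Compound 3 is estimated at 17000 nM, within 6000 nM to 50000 nM, which means an expected step of no change at the digits printed from compound 1 to compound 3 (within the scatter).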

Compound 3, half-maximal cytotoxic concentration: > 100000 nM
Compound 3 ended at the assay's limit; the forecaster's own chance of this, stated with the estimate: 20%; at least 5.8-fold (0.76 log units) between middle value and limit.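

In this assay compound 3 gives > 100000 nM, a limit of the assay and not a number. The acetyl on the nitrogen on an aromatic ring is therefore not a silent position in this test: the change from acetamido to amino gives an at least 5.8-fold higher number from compound 1 to compound 3 (0.76 log units; beyond the scatter), which points to lower toxicity in this test, in the same direction as the change at the aromatic nitrogen, a 2.9-fold higher number from compound 1 to compound 2 (0.47 log units; beyond the scatter). The first of these two steps fixes only a minimum size, and its true size stays unknown, with the top of the range reached on this read-out: the limit of > 100000 nM in this assay, at which 1 of the 3 values shown sits.

The compounds shown leave open whether the free amino group itself matters or whether any replacement of the acetyl would do the same, as a methyl, a longer acyl chain such as propionyl or a methanesulfonyl on that nitrogen could tell. They also leave open whether acetamido to amino reads the same way on the core of compound 2, with hydrogen rather than cyclohexyl on the aromatic nitrogen.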